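This account rests on a few compounds, and the source may have more. Where it says the series, first, only, none or still open, it means among the compounds named here.

Among the compounds with values here, in an ADME assay for permeability, using PAMPA, at pH 7.4 (a lower number here means that the compound crosses the layer more slowly, a higher number that the compound crosses the layer faster), three compounds have numbers so far.

compound 1 `Cc1cc(NC(=O)Nc2ccc(Cl)c(Cl)c2)c2ccccc2n1` gives 197 10^-6 cm/s
compound 2 `CSc1ccc(NC(=O)Nc2cc(C)nc3ccccc23)cc1` gives 473 10^-6 cm/s
compound 3 `COc1ccc(NC(=O)Nc2cc(C)nc3ccccc23)cc1OC` gives 552 10^-6 cm/s

Compound 2 stands within the usual scatter of compound 3, so the two cannot be ordered on these numbers. Compound 1 has a lower number than compound 2, and that gap lies beyond the scatter.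

The next compound to be read is compound 4 `Cc1ccc(NC(=O)Nc2cc(C)nc3ccccc23)cc1`. It differs from compound 2 in one place, with methyl in place of methylsulfanyl on an aromatic carbon, para to a large group (methyl in place of methylsulfanyl on an aromatic carbon).

Within the data shown here, no measured pair differs in only one place, so the data offer no direct step to go by. Compound 2 (473 10^-6 cm/s) and compound 3 (552 10^-6 cm/s) carry different groups on the shared core and still lie within the scatter of each other, so no large step is expected in this assay. Compound 1 (197 10^-6 cm/s) shows that a lower number remains possible on this core. A small fall at most is therefore expected, with the estimated change (a 1.1-fold lower number from compound 2 to compound 4 (0.04 log units; within the scatter)) staying within the scatter. For compound 4 the estimated value is 430 10^-6 cm/s (expected range 230 10^-6 cm/s to 750 10^-6 cm/s).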

Compound 4, apparent permeability: 669 10^-6 cm/s
The estimate for compound 4 lay 1.6-fold (0.19 log units) below the measured number, and the stated range covers the measured number.
By their numbers in this assay, from the lowest: compound 1; then compounds 2, 3 and 4 (each within the scatter of the next).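

In this assay, within the data shown here, the change of methylsulfanyl to methyl on an aromatic carbon, para to a large group, provides the first step between two compounds that differ in one place (a 1.4-fold higher number from compound 2 to compound 4 (0.15 log units; within the scatter)). The step lies within the usual scatter, so at this position the two groups cannot be told apart on these numbers, even though methylsulfanyl carries a sulfur and a hydrogen-bond acceptor that methyl lacks. The compounds shown offer no independent measurement that would account for the size of this step.

Among these compounds, what remains open is how far this position stays insensitive, since methylsulfanyl and methyl are the only two groups compared directly here, and an amine, a carboxylic acid or a longer chain in the same place could give a step of a quite different size. Going by these compounds, it is also open whether the change from methylsulfanyl to methyl would give a step of similar size with other groups elsewhere on the shared core.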